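The compounds below may be only part of what the source reports. "The series", "measured", "known", "first", "only" and "open" are said of these compounds alone.

Measured compounds and their values:
Compound 1, `COc1ccc(-c2nc3cc(C(C)=O)ccc3[nH]2)c(OC)c1`: 50000 nM
Compound 2, `COc1ccc(-c2nc3cc(C(C)=O)ccc3n2C2CCCCC2)c(OC)c1`: 8500 nM
Compound 3, `CC(=O)c1ccc2c(c1)nc(-c1ccoc1)n2C1CCCCC1`: 77000 nM

Of the compounds shown here, three have been measured in an ADME assay on BHK-21 cells (Mesocricetus auratus) for cytotoxicity, read by MTT assay; on this read-out lower numbers stand for higher toxicity in this test and higher numbers for lower toxicity in this test. Compound 2 gives 8500 nM, and compound 1 gives 50000 nM; the difference between them is hydrogen in place of cyclohexyl on an aromatic nitrogen, and that step is a 5.9-fold higher number from compound 2 to compound 1 (0.77 log units; beyond the scatter). Compound 3 gives 77000 nM, a number within the scatter of compound 1 and beyond the scatter of compound 2. The difference between the cores of compound 3 and compound 2 is not broken down here.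

Compound 4, `CC(=O)c1ccc2[nH]c(-c3ccoc3)nc2c1`, has not yet been measured. It differs from compound 3 by hydrogen in place of cyclohexyl on an aromatic nitrogen. This is the same kind of change as that from compound 2 to compound 1, though the place differs in its printed words: in compound 3 the ring atom next to the nitrogen bears a furan-3-yl group (5 heavy atoms), whereas in compound 2 it bears a large group. Because a 5.9-fold higher number from compound 2 to compound 1 (0.77 log units; beyond the scatter) was a rise, compound 4 is expected to show a comparable rise in this assay, estimated as a 3.2-fold higher number from compound 3 to compound 4 (0.51 log units; beyond the scatter). Compound 4 is therefore estimated at 250000 nM, between 80000 nM and 700000 nM, with a real chance that the assay reports only a limit.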

Compound 4, half-maximal cytotoxic concentration: 98000 nM
The estimate for compound 4 lay 2.6-fold (0.41 log units) above the measured number, and the stated range covers the measured number.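

In this assay, putting hydrogen in place of cyclohexyl on the core of compound 3 gives a 1.3-fold higher number from compound 3 to compound 4 (0.10 log units; within the scatter), which leaves the two numbers within the scatter of each other. The size of the step seen on the core of compound 2 therefore does not carry over to the core of compound 3: the same change on two cores in this assay, a 5.9-fold higher number (0.77 log units; beyond the scatter) from compound 2 to compound 1 and a 1.3-fold higher number (0.10 log units; within the scatter) from compound 3 to compound 4, 4.6-fold (0.66 log units) apart, beyond the scatter of two such steps. This shows that, across these two pairs, the outcome of the change depends on the core, but it does not show which feature of the cores is responsible or how the change would behave on any further core, as the two cores differ in the group on the ring atom next to the nitrogen, furan-3-yl in compound 3 and a large group in compound 2.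

The compounds shown leave open whether a phenyl or a pyridine at that ring atom would give a step nearer to the one on compound 2 or the one on compound 3. They also leave open how a methyl group or a longer chain on the aromatic nitrogen would compare with cyclohexyl and hydrogen on either core.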